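Aryl variation on the amide-type nitrogen: compound 3

The compounds below may be only part of what the source reports. "The series", "measured", "known", "first", "only" and "open" are said of these compounds alone.

Measured so far:
compound 1 `COc1cc2ncnc(NCc3cccc(NC(=O)Nc4cccc(C)c4)c3)c2cc1OC` gives 21500 nM in a functional assay on HepG2 cells (Homo sapiens) for antiproliferative activity, read by MTT assay; a higher number here means a weaker inhibitor, a lower number a stronger inhibitor
compound 2 `COc1cc2ncnc(NCc3cccc(NC(=O)Nc4ccccc4F)c3)c2cc1OC` gives 24900 nM in this assay

Compound 2 and compound 1 stand together in this assay: the step of a 1.2-fold higher number from compound 1 to compound 2 (0.06 log units; within the scatter) lies within the scatter, so neither is distinguished from the other. Compound 3 `COc1cc2ncnc(NCc3cccc(NC(=O)Nc4ccc(Cl)cc4)c3)c2cc1OC` differs from compound 2 by 4-chlorophenyl in place of 2-fluorophenyl on an amide-type nitrogen. Within the data shown here, the only measured step at this place, a 1.2-fold higher number from compound 1 to compound 2 (0.06 log units; within the scatter), did not move this assay beyond the scatter; no measured step involves 4-chlorophenyl. The expected step is therefore none beyond the scatter, a 1.2-fold lower number from compound 2 to compound 3 (0.10 log units; within the scatter). Compound 3 is estimated at 20000 nM, with a range from 8000 nM to 50000 nM.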

Compound 3, half-maximal inhibitory concentration: > 50000 nM
Compound 3 ended at the assay's limit; the forecaster's own chance of this, stated with the estimate: 10%; middle value at least 2.5-fold (0.39 log units) from the limit.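

In this assay compound 3 stands at a limit of the assay, not at a number: the limit of > 50000 nM in this assay, at which 1 of the 3 values shown sits.
The aryl group on the amide-type nitrogen is therefore not indifferent to every change: 4-chlorophenyl in place of 3-methylphenyl gives an at least 2.3-fold higher number from compound 1 to compound 3 (0.36 log units; beyond the scatter).
Against 2-fluorophenyl the reading is an at least 2.0-fold higher number from compound 2 to compound 3 (0.30 log units; that floor lies within the scatter), so only the comparison with compound 1 clears the scatter.

From the compounds shown here alone, how far past the limit compound 3 lies stays open. So does whether 4-fluorophenyl, 3-chlorophenyl or a phenyl carrying an amine would stay near compound 1 or also reach the limit.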